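A few compounds are considered here, and "the series" means these few. Any claim that something is new, unique, unknown or untested is made for them only; others in the source may bear on it.

Measured so far in a functional assay on PC-12 cells (Rattus norvegicus) for inhibition, read by MTT assay; a lower number here means that less compound is needed, a higher number that more compound is needed for the effect:
compound 1, `CC1(C)N(O)C(c2ccc(OCC(=O)NCCCC[C@H](N)C(=O)O)cc2)=[N+]([O-])C1(C)C`: 29900 nM
compound 2, `CC(C)(C)OC(=O)N[C@@H](CCCCNC(=O)COc1ccc(C2=[N+]([O-])C(C)(C)C(C)(C)N2O)cc1)C(=O)O`: 29300 nM
compound 3, `CC(C)(C)OC(=O)N[C@@H](CCC(=O)NCCOc1ccc(C2=[N+]([O-])C(C)(C)C(C)(C)N2O)cc1)C(=O)O`: 49900 nM

Going by the values given here, compound 3 has the highest number of the three, but its gap to compound 1 and its gap to compound 2 both lie within the scatter, so these three values give no order among the compounds. Compound 2 and compound 1 differ in one place: hydrogen in place of tert-butoxycarbonyl on an amine nitrogen That change gave a 1.0-fold higher number from compound 2 to compound 1 (0.01 log units; within the scatter), nothing beyond the scatter.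

Compound 4, `CC1(C)N(O)C(c2ccc(OCCNC(=O)CC[C@H](N)C(=O)O)cc2)=[N+]([O-])C1(C)C`, is not yet measured. It stands to compound 3 as compound 1 stands to compound 2: hydrogen in place of tert-butoxycarbonyl on an amine nitrogen The place is the same in both pairs, word for word. How the core of compound 3 differs from the core of compound 2 is not broken down here.

The step from compound 3 to compound 4 in this assay is expected to be a 1.0-fold higher number from compound 3 to compound 4 (0.00 log units; within the scatter), the same size as a 1.0-fold higher number from compound 2 to compound 1 (0.01 log units; within the scatter), which lies within the scatter. Compound 4 is accordingly estimated at 50000 nM, with the number expected to fall between 25000 nM and 100000 nM.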

Compound 4, half-maximal effective concentration: 49600 nM
Beside the measured number, compound 4's estimate is 1.0-fold (0.00 log units) above it, and the stated range covers the measured number.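

In this assay, hydrogen in place of tert-butoxycarbonyl on the amine nitrogen again gives a step within the scatter, a 1.0-fold lower number from compound 3 to compound 4 (0.00 log units; within the scatter). Going by these compounds alone, the change therefore reads the same on both cores, with no difference between the two pairs beyond the scatter: the same change on two cores in this assay, a 1.0-fold higher number (0.01 log units; within the scatter) from compound 2 to compound 1 and a 1.0-fold lower number (0.00 log units; within the scatter) from compound 3 to compound 4, 1.0-fold (0.01 log units) apart, within the scatter of two such steps This does not show that the change would be equally silent on other cores, since it rests on only two matched pairs, and steps this small give no measure of how much a core can alter the result of the change.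

The compounds shown leave open whether a different group on that amine nitrogen, such as an acetyl group or a longer alkyl chain, would move the number beyond the scatter. They also leave open whether a primary amide or a methyl ester in place of the carboxylic acid would do so on either core.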